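The compounds below may be only part of what the source reports. "The series", "measured", "known", "first", "only" and "open" are said of these compounds alone.

Measured so far:
compound 1 `Cc1nc(C(NC(=O)C(=O)Nc2ccc(F)cc2F)C2CCCCN2)sc1CCO`: > 84000 nM
compound 2 `Cc1nc(C(NC(=O)C(=O)Nc2ccc(Cl)cc2)C2CCCNC2)sc1CO`: 60200 nM

In an ADME assay on TZM-b1 cells (Homo sapiens) for cytotoxicity, read by XTT assay, with a stated time of 3 days (a higher number here means that more compound is tolerated, a lower number that less compound is tolerated), compound 1 gives only a limit, > 84000 nM; its place is therefore known just as far as the limit of > 84000 nM in this assay, at which 1 of the 2 values shown sits. Compound 2 gives a number in this assay, 60200 nM. Among the measured compounds shown here, no step between two measured compounds is reported, since compound 2 differs from compound 1 in more than one place.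

Compound 3 `Cc1nc(C(NC(=O)C(=O)Nc2ccc(Cl)cc2)C2CCCCN2)sc1CCO` differs from compound 1 in one place: 4-chlorophenyl in place of 2,4-difluorophenyl on an amide-type nitrogen. Compound 2 also carries a 4-chlorophenyl on an amide-type nitrogen and gives 60200 nM in this assay, near where compound 1 sits. The step is expected to stay within the scatter, an at least 1.2-fold lower number from compound 1 to compound 3 (0.07 log units; that floor lies within the scatter), with no direction called. Compound 3 is estimated at 70000 nM in this assay, ranging from 35000 nM to 140000 nM, with a fair chance that only a limit is reported again.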

Compound 3, half-maximal cytotoxic concentration: 32800 nM
Compound 3: the middle estimate sits 2.1-fold (0.33 log units) above what was measured, and the stated range ends above it.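

In this assay, putting 4-chlorophenyl in place of 2,4-difluorophenyl on an amide-type nitrogen gives an at least 2.5-fold lower number from compound 1 to compound 3 (0.40 log units; beyond the scatter), so this position now has a change that can be read on its own. Compound 1 and compound 2 differ in more than one place, and that pair offered no such reading. Compound 1 gives only a limit, so the step is a floor and its full size stays unknown: the limit of > 84000 nM in this assay, at which 1 of the 3 values shown sits.

Whether the lower number goes with the incoming chlorine or with the loss of the two fluorines stays open, as the compounds shown include neither an unsubstituted phenyl nor a 4-fluorophenyl on that nitrogen. Also open, on these data alone, is whether the same step would hold on the rest of compound 2, which differs from compound 3 elsewhere in the molecule.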